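The source may report more compounds than this note shows. Statements on the series, on what has been measured and on what is new or still open speak of the compounds shown alone.

In a functional assay on MCF7 cells (Homo sapiens) for antiproliferative activity, read by MTT assay, with a stated time of 72 h (a lower number here means a stronger inhibitor, a higher number a weaker inhibitor), compound 1 `CNc1nc(-c2cc(OC)c(OC)c(OC)c2)c(-c2ccc3ccccc3c2)s1` gives 21.1 nM and compound 2 `COc1cc(-c2nc(N(C)C)sc2-c2ccc3ccccc3c2)cc(OC)c1OC` gives 2390 nM as the higher of the two numbers. Compound 3 `COc1cc(-c2nc(N(C)C)sc2-c2ccc(C(F)(F)F)cc2)cc(OC)c1OC` keeps the dimethylamino group and changes at one place: 4-(trifluoromethyl)phenyl in place of naphthalen-2-yl on an aromatic carbon. Going by the values given here, the only measured step of a 110-fold higher number from compound 1 to compound 2 (2.05 log units; beyond the scatter) lies on the nitrogen and not at this place, so it gives no size for this change. In this assay the expected step is a 1.3-fold higher number from compound 2 to compound 3 (0.10 log units; within the scatter) and no clear direction is expected. Compound 3 is estimated at 3000 nM with an expected range from 700 nM to 12000 nM for the measurement.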

Compound 3, half-maximal inhibitory concentration: > 10000 nM
Compound 3: a limit, no number; the forecaster's own chance of this, stated with the estimate: 20%; at least 3.3-fold (0.52 log units) between middle value and limit.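

In this assay, 4-(trifluoromethyl)phenyl in place of naphthalen-2-yl gives an at least 4.1-fold higher number from compound 2 to compound 3 (0.62 log units; beyond the scatter), so this aromatic carbon, which the earlier step on the nitrogen left untouched, also responds to change. Compound 3 is recorded only as a limit and not as a number: the limit of > 10000 nM in this assay, at which 1 of the 3 values shown sits.

The compounds shown leave open whether this loss follows from removing the second aromatic ring or from adding trifluoromethyl, which a plain phenyl or a 4-methoxyphenyl group here would help separate. They also leave open how the same change would read with the methylamino group of compound 1.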